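A few compounds are considered here, and "the series" means these few. Any claim that something is new, unique, unknown or untested is made for them only; others in the source may bear on it.

Measured so far in an ADME assay (Rattus norvegicus, strain Han-wistar) for pharmacokinetics, at a dose of 1.5 umol/kg by the intravenous route (on this read-out lower numbers stand for narrower distribution and higher numbers for wider distribution into tissues), are these compounds:
- Compound 1 (`CNC(=O)CN1CCC(c2cc3c(-c4ccc(=O)n(C(C)C)c4)ccnc3[nH]2)CC1`) gives 2.6 L/kg
- Compound 2 (`CC(C)n1cc(-c2ccnc3[nH]c(C4CCN(CC(=O)N5CCCC5)CC4)cc23)ccc1=O`) gives 3.9 L/kg

Compound 2 lies within the scatter of compound 1, and the pair sets no order on this assay as it stands. Next is compound 3 (`CC(C)n1cc(-c2ccnc3[nH]c(C4CCN(Cc5cccs5)CC4)cc23)ccc1=O`), which differs from compound 2 thus: thiophen-2-yl in place of (pyrrolidin-1-yl)carbonyl on a saturated chain carbon bound to an amine nitrogen in a ring with thiophen-2-yl in place of (pyrrolidin-1-yl)carbonyl on a saturated chain carbon bound to an amine nitrogen in a ring. For the measured compounds named here, the one measured step, a 1.5-fold higher number from compound 1 to compound 2 (0.18 log units; within the scatter) and within the scatter, changes only the group on the carbonyl carbon. Going by the values given here, it bears loosely on the new change, in which the carbonyl leaves too, and no measured step covers that loss. No step beyond the scatter is expected, with a slight upward lean. The estimated step is a 1.2-fold higher number from compound 2 to compound 3 (0.06 log units; within the scatter) and remains an expectation. Compound 3 is expected at 4.5 L/kg with an estimated range from 2.2 L/kg to 9 L/kg on this read-out.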

Compound 3, volume of distribution: 1.6 L/kg
Compound 3: the middle estimate sits 2.8-fold (0.45 log units) above what was measured; measured number outside the range, below it.
By their numbers in this assay, from the lowest: compounds 3, 1 and 2 (each within the scatter of the next, the first and the last beyond it).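

In this assay, for the compounds shown here, thiophen-2-yl on the saturated chain carbon bound to an amine nitrogen in a ring gives the only step beyond the scatter seen so far at this position: a 2.4-fold lower number from compound 2 to compound 3 (0.39 log units; beyond the scatter). The same replacement measured against methylcarbamoyl stays within the scatter, a 1.6-fold lower number from compound 1 to compound 3 (0.21 log units; within the scatter), so compound 1 goes against any general lowering, and the effect of leaving the amide series rests on one modest step. Nothing measured here accounts for the shift.

On these data alone, in compound 3 the carbonyl leaves and the thiophen-2-yl ring enters in one change, and the share of each in the step stays open. A phenyl ring or a carboxylic acid on the same chain carbon would test how far the lower number depends on the entering ring.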